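Swapping the benzyl halide for a pyridylmethyl on a sulfamate

The source may report more compounds than this note shows. Statements on the series, on what has been measured and on what is new or still open speak of the compounds shown alone.

Measured compounds:
compound 1 `CCN(Cc1ccc(Br)cc1)c1cccc(C(=O)N2CCc3ccc(OS(N)(=O)=O)cc3C2)c1`: 24.2%
compound 2 `CCCN(CCC)c1ccc(C(=O)N2CCc3ccc(OS(N)(=O)=O)cc3C2)cc1`: 36.6%

The two measured compounds share a sulfamate-bearing core and differ in the amine substituent on the benzamide. In an assay on HEK293 cells for inhibition of Steryl-sulfatase (Homo sapiens), tested at 0.1 uM (on this read-out lower numbers stand for a weaker effect and higher numbers for a stronger effect at the one concentration tested), compound 1 gives 24.2%, the lower of the two numbers. Compound 2 gives 36.6% in this assay, a number that lies beyond the scatter above compound 1. Among the compounds with values here, no single-point step between these two is defined, since they differ in more than one place.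

Compound 3 `CCN(Cc1ccccn1)c1cccc(C(=O)N2CCc3ccc(OS(N)(=O)=O)cc3C2)c1` is not yet measured. It differs from compound 1 in one place: pyridin-2-yl in place of 4-bromophenyl on a saturated chain carbon bound to a nitrogen on an aromatic ring. Within the data shown here, with no measured step of this kind to lean on, the expectation is modest: the step of a number 4.2 percentage points lower from compound 1 to compound 3 (within the scatter) is expected to stay within the usual scatter, with a slight lean downward. Compound 3 is therefore estimated at 20%, with a range from 5% to 40%.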

Compound 3, a percentage reported as inhibition, at one concentration (the size of the read-out at that concentration, not a potency): 6.5%
Compound 3: the middle estimate sits 13.5 percentage points above what was measured, and the stated range covers the measured number.
By their numbers in this assay, from the lowest: compound 3; then compound 1; then compound 2.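

In this assay, within the data shown here, the exchange of 4-bromophenyl for pyridin-2-yl on a saturated chain carbon bound to a nitrogen on an aromatic ring is the first change in a single place, and it gives a number 17.7 percentage points lower from compound 1 to compound 3 (beyond the scatter). Among these compounds, the earlier pair differed in more than one place, so only this step shows that the read-out responds to the aromatic ring carried on this chain carbon. Nothing available explains the size or direction of this step.

The two compounds leave open whether the step follows the loss of the bromine or the arrival of the ring nitrogen, a question that an unsubstituted phenyl on the same carbon could help to separate. From the compounds shown here alone, how pyridin-3-yl or pyridin-4-yl would compare with pyridin-2-yl also remains open.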